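Swapping the pyrazole for a diisopropylamino group

The source may report more compounds than this note shows. Statements on the series, on what has been measured and on what is new or still open speak of the compounds shown alone.

Measured so far:
compound 1, `CN(Cc1ccccc1)Cc1ncnc2c1ncn2[C@@H]1O[C@H](CO)[C@@H](O)[C@H]1O`, 9000 nM
compound 2, `OC[C@H]1O[C@@H](n2cnc3c(Cn4cccn4)ncnc32)[C@H](O)[C@@H]1O`, > 250000 nM

In a functional assay on Huh-7 cells (Homo sapiens) for cytotoxicity, read by MTT assay, with a stated time of 3 days (a higher number here means that more compound is tolerated, a lower number that less compound is tolerated), compound 1 gives 9000 nM. For compound 2 this assay reports only a limit, > 250000 nM, with no number behind it, as noted in the limit of > 250000 nM in this assay, at which 1 of the 2 values shown sits. Within the data shown here, the single measured step, an at least 27-fold higher number from compound 1 to compound 2 (1.44 log units; beyond the scatter), is therefore known only as a lower bound. Compound 3, `CC(C)N(Cc1ncnc2c1ncn2[C@@H]1O[C@H](CO)[C@@H](O)[C@H]1O)C(C)C`, has not yet been measured. It differs from compound 2 by diisopropylamino in place of 1H-pyrazol-1-yl on a saturated chain carbon bound to an aromatic carbon. This change puts an amino group back on the same carbon that carried benzyl(methyl)amino in compound 1, so the step from compound 2 to compound 3 is expected to run opposite to the step from compound 1 to compound 2, back toward a lower number. The expected step is an at least 10-fold lower number from compound 2 to compound 3 (1.00 log units; beyond the scatter). Compound 3 is thus estimated at 25000 nM, within 6000 nM to 150000 nM.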

Compound 3, half-maximal cytotoxic concentration: 18000 nM
The estimate for compound 3 lay 1.4-fold (0.14 log units) above the measured number; low and high end bracket the measured number.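

In this assay, replacing 1H-pyrazol-1-yl with diisopropylamino gives an at least 13-fold lower number from compound 2 to compound 3 (1.14 log units; beyond the scatter), so the high number of the pyrazole compound does not carry over to this amino group. The size of that step is only a lower bound, since one of its ends is a limit: the limit of > 250000 nM in this assay, at which 1 of the 3 values shown sits. Exchanging benzyl(methyl)amino for diisopropylamino gives a 2.0-fold higher number from compound 1 to compound 3 (0.30 log units; within the scatter), so these two amino groups cannot be told apart in this assay, and the benzyl group is not needed for a number in this range.

Three compounds cannot show whether amino groups in general behave this way or what sets 1H-pyrazol-1-yl apart. A small amine such as dimethylamino, a ring amine such as piperidin-1-yl, or another aromatic ring such as imidazol-1-yl on this carbon would test that.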